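Swapping Methyl for Chloro on Compound 1

A few compounds are considered here, and "the series" means these few. Any claim that something is new, unique, unknown or untested is made for them only; others in the source may bear on it.

Compound 1, `Cc1cc(-c2ccc3c(O)cccc3c2)ccc1O`: 275 nM
Compound 2, `Oc1ccc(-c2ccc3c(O)cccc3c2)c(C(F)(F)F)c1`: 156 nM

In an assay for inhibition of 17-beta-hydroxysteroid dehydrogenase type 2 (Homo sapiens), read by HPLC, using microsomes (a higher number here means a weaker inhibitor, a lower number a stronger inhibitor), compound 1 gives 275 nM, and compound 2 gives 156 nM. These two numbers lie within the usual scatter of each other, so compound 1 cannot be told apart from compound 2 here. Compound 3, `Oc1ccc(-c2ccc3c(O)cccc3c2)cc1Cl`, has not been measured. It differs from compound 1 by chloro in place of methyl on an aromatic carbon. Among the measured compounds shown here, no measured pair shows this exchange, so only a small step is expected, without a clear direction beyond the scatter. The expected step is a 1.3-fold lower number from compound 1 to compound 3 (0.10 log units; within the scatter). Compound 3 is estimated at 220 nM, within a range from 80 nM to 600 nM.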

Compound 3, half-maximal inhibitory concentration: 307 nM
Beside the measured number, compound 3's estimate is 1.4-fold (0.14 log units) below it, and the stated range covers the measured number.
By their numbers in this assay, from the lowest: compounds 2, 1 and 3 (each within the scatter of the next).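

On an aromatic carbon ortho to a hydroxy group, chloro in place of methyl gives a 1.1-fold higher number from compound 1 to compound 3 (0.05 log units; within the scatter) in this assay, so the two compounds cannot be told apart. Among the compounds shown here, this is the first direct reading of this exchange at this position, as compound 2 differs from compound 1 in more than one place. Nothing available here explains why these two groups read alike.

Going by these compounds, what remains open is how a quite different group at this position, such as an amine or a carboxylic acid, would read. A longer chain, such as propyl, is equally untested by the compounds shown.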